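Replacing 4-carboxyphenyl with 3-acetylphenyl in a growth inhibition series

This account rests on a few compounds, and the source may have more. Where it says the series, first, only, none or still open, it means among the compounds named here.

In a functional assay on UO-31 cells (Homo sapiens) for inhibition, read by sulforhodamine B assay, with a stated time of 48 h, tested at 10 uM (a higher number here means more inhibition of growth at the concentration tested, a lower number less inhibition of growth), compound 1 (`CCOC(=O)c1ccc(Nc2ccnc(SCC(=O)c3ccc([N+](=O)[O-])cc3)n2)cc1`) gives 41% while compound 2 (`O=C(O)c1ccc(Nc2ccnc(SCC(=O)c3ccc(C(F)(F)F)cc3)n2)cc1`) gives 32% and compound 3 (`CC(=O)c1ccc(Nc2ccnc(SCC(=O)c3ccc(Cl)cc3)n2)cc1`) gives 33% on the same scale. Compound 2 lies within the usual scatter of both other compounds, so these numbers set no order among the three.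

Compound 4 (`CC(=O)c1cccc(Nc2ccnc(SCC(=O)c3ccc(C(F)(F)F)cc3)n2)c1`) has not yet been measured. It differs from compound 2 in one place, with 3-acetylphenyl in place of 4-carboxyphenyl on a nitrogen on an aromatic ring. For the measured compounds named here, no measured pair isolates a single change, so this step has no direct precedent. Compound 3 also carries an acetyl group and gives 33% within the scatter of compound 2, so no step beyond the scatter is expected in this assay in either direction. The estimated change is a number 3 percentage points higher from compound 2 to compound 4 (within the scatter) and stays within the scatter. For compound 4 the expected value is 35% with an estimated range from 22% to 50% in this measurement.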

Compound 4, percent growth inhibition at one concentration: 57%
Estimate against measurement, compound 4: 22 percentage points below; the measured number lies above the stated range.
By their numbers in this assay, from the lowest: compounds 2, 3 and 1 (each within the scatter of the next); then compound 4.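

In this assay, for the compounds shown here, the change from 4-carboxyphenyl to 3-acetylphenyl on a nitrogen on an aromatic ring gives a number 25 percentage points higher from compound 2 to compound 4 (beyond the scatter), the first single change that can be read. Going by these compounds alone, it shows that the group at this position alone can shift growth inhibition beyond the scatter while the rest of compound 2 stays the same, which the earlier compounds, all differing in more than one place, could not show. No measurement shown here accounts for this step.

The change alters both the group and its place on the ring, so the compounds shown leave open which of the two matters, and 3-carboxyphenyl or 4-acetylphenyl on the same nitrogen would separate them. Going by these compounds, it also remains open whether an amide or a nitrile in place of the acetyl group would keep the level of compound 4 at 57%.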